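Swapping fluoro for methoxy on compound 3

The source may report more compounds than this note shows. Statements on the series, on what has been measured and on what is new or still open speak of the compounds shown alone.

Three relatives sharing one core have been tested in an ADME assay on HPLF cells (Homo sapiens) for cytotoxicity, with a stated time of 24 h; on this read-out lower numbers stand for higher toxicity in this test and higher numbers for lower toxicity in this test. Compound 1 (`O=C1/C(=C/c2ccc(Cl)cc2)CCC/C1=C\c1ccccc1[N+](=O)[O-]`) reaches only a limit of the assay, > 400000 nM. Compound 2 (`COc1ccc(/C=C2\CCC/C(=C\c3ccccc3[N+](=O)[O-])C2=O)cc1`) gives 386000 nM. Compound 3 (`O=C1/C(=C/c2ccc(F)cc2)CCC/C1=C\c1cccc([N+](=O)[O-])c1`) gives 36000 nM, the lower of the two results that are actual numbers, and its gap to compound 2 lies beyond the scatter.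

Compound 4 (`COc1ccc(/C=C2\CCC/C(=C\c3cccc([N+](=O)[O-])c3)C2=O)cc1`) has not yet been measured. It differs from compound 3 in one place: methoxy in place of fluoro on an aromatic carbon. This is methoxy in place of fluoro on an aromatic carbon, para to a large group.

Within the data shown here, one measured step bears on this swap: an at least 1.0-fold lower number from compound 1 to compound 2 (0.01 log units; that floor lies within the scatter), with methoxy in place of chloro on an aromatic carbon. That figure is only a floor, since one end of the step sits at the limit of > 400000 nM in this assay, at which 1 of the 3 values shown sits. It shows no change beyond the scatter, but it cannot rule one out. The group leaving there is also chloro rather than fluoro, and compound 1 and compound 2 differ from compound 3 elsewhere too. The evidence therefore points to no clear direction. The estimated change is a 1.1-fold higher number from compound 3 to compound 4 (0.05 log units; within the scatter), which is expected to stay within the scatter. For compound 4 the expected value is 40000 nM, with an estimated range from 15000 nM to 110000 nM.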

Compound 4, half-maximal cytotoxic concentration: 354000 nM
Estimate against measurement, compound 4: 8.9-fold (0.95 log units) below, and the stated range ends below it.
By their numbers in this assay, from the lowest: compound 3; then compounds 4 and 2 (each within the scatter of the next). At a limit, above all of these: compound 1.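

In this assay, going from 4-fluorophenyl to 4-methoxyphenyl gives a 9.8-fold higher number from compound 3 to compound 4 (0.99 log units; beyond the scatter), so this single change, on an aromatic carbon para to a large group, moves the read-out clearly towards lower toxicity in this test. Among these compounds, this is the first step for a methoxy swap at this position with a real number at both ends, since the earlier step, with chloro leaving, yielded only a floor: the limit of > 400000 nM in this assay, at which 1 of the 4 values shown sits. Within this pair, the lower number of compound 3 goes with its fluoro group, although a single pair says nothing about fluoro across the series.

Going by these compounds, whether the rise belongs to methoxy alone or would also come with other groups at this position, such as a hydroxyl, an amine or a longer chain like ethoxy, stays open. Also open is whether a step of this size would hold for the same swap elsewhere in the series, as the only other methoxy step shown starts from a limit and from chloro rather than fluoro.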